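The compounds below may be only part of what the source reports. "The series", "measured", "known", "first", "only" and "open" are said of these compounds alone.

Measured compounds:
Compound 1, `O=c1ccc2nc(-c3ccccc3)nn(-c3ccccc3)c-2c1`, gives 230 nM in a functional assay on DU-145 cells (Homo sapiens) for cytotoxicity, read by MTT assay, with a stated time of 72 h; a higher number here means a weaker inhibitor, a lower number a stronger inhibitor.
Compound 2, `Nc1cc2nc(-c3ccccc3)nn(-c3ccccc3)c-2cc1=O`, gives 1830 nM in this assay.
Compound 3, `CCNc1cc2nc(-c3ccccc3)nn(-c3ccccc3)c-2cc1=O`, gives 220 nM in this assay.

Among these three numbers, compound 3 sits at the low end together with compound 1, the gap between them being a 1.0-fold lower number from compound 1 to compound 3 (0.02 log units; within the scatter), which is within the scatter; only compound 2 is set apart, by an 8.3-fold lower number from compound 2 to compound 3 (0.92 log units; beyond the scatter).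

Compound 4, `O=c1cc2n(-c3ccccc3)nc(-c3ccccc3)nc-2cc1N1CCCCC1`, differs from compound 3 in one place: piperidin-1-yl in place of ethylamino on an aromatic carbon. Among the compounds with values here, two measured steps touch this same position. The step of an 8.0-fold higher number from compound 1 to compound 2 (0.90 log units; beyond the scatter) shows that amino in place of hydrogen raised the number beyond the scatter, while an 8.3-fold lower number from compound 2 to compound 3 (0.92 log units; beyond the scatter) shows that ethyl on that nitrogen brought it back down, so that overall a 1.0-fold lower number from compound 1 to compound 3 (0.02 log units; within the scatter) is no change beyond the scatter. Within the data shown here, no measured step removes the hydrogen-bond donor while keeping the nitrogen, or places a six-membered non-aromatic ring there, so the evidence for compound 4 is thin. Because compound 3 and compound 1 are tied by a 1.0-fold lower number from compound 1 to compound 3 (0.02 log units; within the scatter), a step within the scatter or a small rise is expected, namely a 1.6-fold higher number from compound 3 to compound 4 (0.20 log units; within the scatter). Compound 4 is therefore estimated at 350 nM, with a range from 120 nM to 1500 nM in this assay.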

Compound 4, half-maximal inhibitory concentration: 610 nM
Compound 4: the middle estimate sits 1.7-fold (0.24 log units) below what was measured; measured number inside the range.
By their numbers in this assay, from the lowest: compounds 3 and 1 (each within the scatter of the next); then compound 4; then compound 2.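

In this assay, the change from ethylamino to piperidin-1-yl is a step beyond the scatter (a 2.8-fold higher number from compound 3 to compound 4 (0.44 log units; beyond the scatter)), so this position does not treat every group joined through nitrogen alike. Earlier, ethylamino could not be told apart from hydrogen, but piperidin-1-yl can be, as it gives a higher number than the unsubstituted compound (a 2.7-fold higher number from compound 1 to compound 4 (0.42 log units; beyond the scatter)) while still giving a lower number than the amino compound (a 3.0-fold lower number from compound 2 to compound 4 (0.48 log units; beyond the scatter)), which places it in the middle of the series. Nothing available on these compounds offers an explanation for these steps.

The change from ethylamino to piperidin-1-yl adds a ring and loses the hydrogen on the nitrogen in a single step, so the compounds shown cannot say which of these two differences goes with the higher number. A diethylamino group would lose that hydrogen without adding a ring, and a cyclohexylamino group would add a ring while keeping it, so the pair could pull the two differences apart.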